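The source may report more compounds than this note shows. Statements on the series, on what has been measured and on what is new or still open speak of the compounds shown alone.

Measured in an assay on isolated protein for inhibition of DNA topoisomerase 1 (Homo sapiens), with a stated time of 30 min, tested at 20 uM; on this read-out lower numbers stand for a weaker effect and higher numbers for a stronger effect at the one concentration tested:

compound 1, `Cc1ccc2c(=O)[nH]c(-c3ccccc3N(C)C)nc2c1`, gives 5.3%;
compound 2, `CCN(CC)c1ccc2nc(-c3cccc4ccccc34)[nH]c(=O)c2c1`, gives 25.5%;
compound 3, `Cc1ccc2c(=O)[nH]c(-c3cccc(F)c3)nc2c1`, gives 4.3%.

Among these three numbers compound 1 stands second highest. Its nearest neighbour is compound 3, whose value lies within the usual scatter of it, so the two cannot be told apart. Compound 2 lies furthest away, with a value beyond the scatter above that of compound 1. No pair of these compounds differs in only one place, so no single step between measured compounds is available as a guide.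

The unmeasured compound 4, `Cc1ccc2c(=O)[nH]c(-c3ccccc3OC(F)(F)F)nc2c1`, departs from compound 1 in one place: trifluoromethoxy in place of dimethylamino on an aromatic carbon. Among the measured compounds shown here, with no matching step in hand, the size of this change is open. The low values of compound 1 and compound 3 in this assay suggest that this shared core, carrying one small group on the pendant ring, tends to give weak read-outs, and compound 4 keeps a single small group there. The step from compound 1 to compound 4 is therefore expected to be small, a number 1.7 percentage points higher from compound 1 to compound 4 (within the scatter), most likely not beyond the scatter in either direction. Compound 4 is estimated at 7%, with a range from 0% to 20%.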

Compound 4, a percentage reported as inhibition, at one concentration (the size of the read-out at that concentration, not a potency): 100%
For compound 4 the middle estimate is 93 percentage points below the measured one; the whole stated range lies below it.
By their numbers in this assay, from the lowest: compounds 3 and 1 (each within the scatter of the next); then compound 2; then compound 4.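

Exchanging dimethylamino for trifluoromethoxy on this aromatic carbon, ortho to a large group, gives in this assay a large step, a number 94.7 percentage points higher from compound 1 to compound 4 (beyond the scatter), so this one place on the shared core is far from indifferent to what it carries. The earlier compounds shown here could not show this, since no pair of them differed in only one place. The two groups have the same counts of hydrogen-bond donors and acceptors and neither has a net charge, so those counts do not separate them; they differ in size and in their atoms, with oxygen and fluorine entering where nitrogen leaves.

Nothing given here bears on why this change has so large an effect. On these data alone, it remains open how methoxy, trifluoromethyl or a chlorine atom on the same carbon would read out, and so whether the step belongs to trifluoromethoxy alone.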